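The compounds below may be only part of what the source reports. "The series", "measured", "known", "first", "only" and "open" are said of these compounds alone.

Compound 1, `Cc1nn2c(-c3nc4cc(C(F)(F)F)ccc4[nH]3)c(-c3ccccc3)nc2s1`, gives 13600 nM in a functional assay on A549 cells (Homo sapiens) for antiproliferative activity, read by MTT assay; on this read-out higher numbers stand for weaker inhibition and lower numbers for stronger inhibition. Compound 2, `Cc1nn2c(-c3nc4cc(C(F)(F)F)ccc4[nH]3)c(-c3ccc(F)cc3)nc2s1`, gives 12700 nM in this assay. Compound 3, `Cc1ccc(-c2nc3sc(C)nn3c2-c2nc3cc(Cl)ccc3[nH]2)cc1`, gives 4400 nM in this assay.

Compound 1 and compound 2 share a core and differ only in that compound 2 carries fluoro in place of hydrogen on an aromatic carbon. That change made a 1.1-fold lower number from compound 1 to compound 2 (0.03 log units; within the scatter). Compound 3 rests on a different core; the difference between the two cores is not broken down here. Its value stands below those of both compound 1 and compound 2 by a gap that lies beyond the usual scatter.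

Compound 4, `Cc1ccc(-c2nc3sc(C)nn3c2-c2nc3cc(Cl)c(F)cc3[nH]2)cc1`, has not yet been measured. It differs from compound 3 by fluoro in place of hydrogen on an aromatic carbon. This is the same kind of change as that from compound 1 to compound 2, but not the same change: in compound 2 the fluoro enters a six-membered aromatic ring of carbon only, para to a large group, whereas in compound 4 it enters a six-membered aromatic ring of carbon only that is part of a fused system of two rings, ortho to a chloro group, meta to a fused ring and para to a fused ring.

Going by the values given here, the one measured example of this kind of change, from compound 1 to compound 2, stayed within the scatter. On that basis, and because compound 3 gives 4400 nM, compound 4 is expected to give 4200 nM in this assay, with a range from 1800 nM to 10000 nM, a step estimated at a 1.0-fold lower number from compound 3 to compound 4 (0.02 log units; within the scatter). The different surroundings of the entering fluoro in compound 4 mean this expectation carries more uncertainty than a simple repeat would.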

Compound 4, half-maximal inhibitory concentration: 10300 nM
Beside the measured number, compound 4's estimate is 2.5-fold (0.39 log units) below it, outside the stated range (above it).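

Fluoro in place of hydrogen on an aromatic carbon, entering ortho to a chloro group in a ring that is part of a fused system of two rings, gave a 2.3-fold higher number from compound 3 to compound 4 (0.37 log units; beyond the scatter) in this assay, a modest weakening of inhibition. Set beside the earlier example of this kind of change, the new step cannot be told apart from it, even though only the new step lies beyond the scatter when taken alone: the same change on two cores in this assay, a 1.1-fold lower number (0.03 log units; within the scatter) from compound 1 to compound 2 and a 2.3-fold higher number (0.37 log units; beyond the scatter) from compound 3 to compound 4, 2.5-fold (0.40 log units) apart, within the scatter of two such steps

The pair therefore does not show that the change behaves differently on the two cores, and it does not show that its effect carries over unchanged from one core to the other. With a single step on each core and the fluoro entering a different ring in each, any influence of the core cannot be separated from that of the place where the fluoro sits.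

The compounds shown leave open whether fluoro in the fused system of two rings would give a similar step on the core of compound 1, and whether that step depends on the neighbouring chloro group. They also leave open how a methoxy group or an amine in the same place would compare with fluoro.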